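The source may hold more compounds than are shown below. What is called first, only, known or untested is meant among the compounds shown, and "the series" means these compounds.

Measured so far:
compound 1 `CCCNC(=C\C(=O)/C=C/c1ccc(O)c(OC)c1)/C=C/c1ccc(O)c(OC)c1` gives > 25000 nM (a limit)
compound 2 `COc1cc(/C=C/C(=O)/C=C(/C=C/c2ccc(O)c(OC)c2)NC2CCCCC2)ccc1O` gives > 25000 nM (a limit)

In a functional assay on CHO-K1 cells (Cricetulus griseus) for inhibition, read by sulforhodamine B assay, with a stated time of 72 h (a lower number here means a stronger inhibitor, a higher number a weaker inhibitor), compound 2 gives > 25000 nM, a limit and not a number. Compound 3 `CCCCNC(=C\C(=O)/C=C/c1ccc(O)c(OC)c1)/C=C/c1ccc(O)c(OC)c1` carries butyl in place of cyclohexyl on an amine nitrogen. Going by the values given here, the only measured step that bears on this, a step that the two limits leave unreadable from compound 1 to compound 2, has no readable size. Compound 1 and compound 2 both sit at the same limit (the limit of > 25000 nM in this assay, at which 2 of the 2 values shown sit). No step beyond the scatter is expected, in either direction. The estimated change is a step that the limit leaves unreadable from compound 2 to compound 3. For compound 3 the expected value is 30000 nM, with an estimated range of 15000 nM to 60000 nM.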

Compound 3, half-maximal inhibitory concentration: 20400 nM
Estimate against measurement, compound 3: 1.5-fold (0.17 log units) above; the measured number falls inside the stated range.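

In this assay compound 3 gives 20400 nM, so butyl on the amine nitrogen yields a number. The other two compounds remain limits: the limit of > 25000 nM in this assay, at which 2 of the 3 values shown sit. Butyl in place of cyclohexyl gives an at least 1.2-fold lower number from compound 2 to compound 3 (0.08 log units; that floor lies within the scatter), and the change from propyl gives an at least 1.2-fold lower number from compound 1 to compound 3 (0.08 log units; that floor lies within the scatter); these are floors only, and the step between the two limits cannot be read.

On these data alone, whether ring or open chain matters on this nitrogen stays open. So does whether a longer chain such as hexyl, or a chain ending in a carboxylic acid, moves the value beyond the scatter.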